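The source may hold more compounds than are shown below. What is called first, only, known or untested is meant among the compounds shown, and "the series" means these compounds.

Three compounds that share one core were tested in an ADME assay on HCT-116 cells (Homo sapiens) for cytotoxicity, read by CellTiter-Glo, with a stated time of 72 h; a higher number here means a weaker inhibitor, a lower number a stronger inhibitor. Compound 1 `CC1CCN(C2CCN(S(=O)(=O)c3cccnc3Cl)CC2)CC1` gives > 10000 nM, which is a limit of the assay and not a number. Compound 2 `Cc1cccc(S(=O)(=O)N2CCC(N3CCC(C)CC3)CC2)c1` gives > 5000 nM, also a limit. Compound 3 `CC1CCN(C2CCN(S(=O)(=O)c3ccc(Cl)cc3Cl)CC2)CC1` gives > 5000 nM, again a limit. With the limit of > 10000 nM in this assay, at which 1 of the 3 values shown sits, and the limit of > 5000 nM in this assay, at which 2 of the 3 values shown sit, covering all three values, none of the steps among them can be read: a step that the two limits leave unreadable from compound 1 to compound 2, a step that the two limits leave unreadable from compound 1 to compound 3 and a step that the two limits leave unreadable from compound 2 to compound 3. So compound 3 stands at a limit, and the two further values are limits too, so no compound can be ranked against another.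

Compound 4 `CC1CCN(C2CCN(S(=O)(=O)c3cccc(N)c3)CC2)CC1` differs from compound 3 in one place: 3-aminophenyl in place of 2,4-dichlorophenyl on a sulfonyl sulfur. Among the measured compounds shown here, the steps that bear on this change are those that also swap the group on the sulfonyl sulfur, from compound 1 to compound 3 and from compound 2 to compound 3, and both are of unreadable size. For the measured compounds named here, no direction and no size of step can therefore be expected in this assay beyond what the limits allow; the plain expectation is that compound 4 will also be reported as a limit. Compound 4 is estimated at 20000 nM, with a range from 5000 nM to 100000 nM. That estimate means an expected step that the limit leaves unreadable from compound 3 to compound 4.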

Compound 4, half-maximal inhibitory concentration: > 5000 nM
Compound 4: only a limit was reported; the forecaster's own chance of this, stated with the estimate: 85%; the middle value lies beyond the limit too.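

Among the compounds shown here, compound 4 is reported only as a limit of the assay and not a number, as are compound 1, compound 2 and compound 3, so no step involving compound 4 can be read in this assay. One limit applies to compound 1: the limit of > 10000 nM in this assay, at which 1 of the 4 values shown sits. The other applies to compound 2, compound 3 and compound 4: the limit of > 5000 nM in this assay, at which 3 of the 4 values shown sit. The compounds shown leave open how strongly any of them inhibits these cells, and whether the group on the sulfonyl sulfur changes that at all.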